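Changing the benzamide substituent in a chromone-bearing series

The source may hold more compounds than are shown below. What is called first, only, known or untested is meant among the compounds shown, and "the series" means these compounds.

Of the compounds shown here, three have been measured in an assay on isolated protein for inhibition of Rho-associated protein kinase 2 (Homo sapiens), read by scintillation counting, radiometric assay and 33P incorporation, with a stated time of 40 min, in the presence of a further agent that is not named here; a higher number here means a weaker inhibitor, a lower number a stronger inhibitor. Compound 1 `CC(=O)c1ccc(OCC(=O)Nc2cccc(NC(=O)c3ccc(N(C)C)cc3)c2)cc1F` gives 98 nM. Compound 2 `CN(C)c1ccc(C(=O)Nc2cccc(NC(=O)COc3ccc4occc(=O)c4c3)c2)cc1` gives only a limit of the assay, > 10000 nM. Compound 3 `Cc1ccc(C(=O)Nc2cccc(NC(=O)COc3ccc4c(=O)ccoc4c3)c2)cc1` gives 22 nM, the lowest of the two numbers shown; compound 1 sits an at least 100-fold higher number from compound 1 to compound 2 (2.00 log units; beyond the scatter) away from compound 2, while compound 3 stands below compound 1 by a margin beyond the usual scatter.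

Compound 4 `O=C(COc1ccc2c(=O)ccoc2c1)Nc1cccc(NC(=O)c2ccc(OC(F)(F)F)cc2)c1` differs from compound 3 in one place: trifluoromethoxy in place of methyl on an aromatic carbon, on the amide-bearing ring of the shared core. Among the measured compounds shown here, the one measured step, an at least 100-fold higher number from compound 1 to compound 2 (2.00 log units; beyond the scatter), concerns the other end of the molecule, where the ether-linked ring was exchanged, and so it does not bear on the present change. For the measured compounds named here, no measured pair shows what trifluoromethoxy in place of methyl does here.

Going by the values given here, with no step to lean on, compound 4 is expected to stay near compound 3, with a step of a 1.8-fold higher number from compound 3 to compound 4 (0.26 log units; within the scatter) in this assay, and its estimated value is 40 nM, between 10 nM and 200 nM.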

Compound 4, half-maximal inhibitory concentration: 77 nM
Compound 4: the middle estimate sits 1.9-fold (0.28 log units) below what was measured; low and high end bracket the measured number.
By their numbers in this assay, from the lowest: compound 3; then compounds 4 and 1 (each within the scatter of the next). At a limit, above all of these: compound 2.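

In this assay, among the compounds shown here, putting trifluoromethoxy in place of methyl on the aromatic carbon para to a large group gives a 3.5-fold higher number from compound 3 to compound 4 (0.54 log units; beyond the scatter), the first measured step at this end of the molecule. This shows that the position responds to what it carries, although the step is only modest, so a group with more heavy atoms than methyl is accepted here and inhibition is not lost. Nothing measured here accounts for the size of this step.

For the compounds shown here, with only two groups compared at this position, one pair cannot show which difference between them matters. From the compounds shown here alone, how a small group such as fluorine, or a carboxylic acid or a primary amine, would behave on this same aromatic carbon remains open.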